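A few compounds are considered here, and "the series" means these few. Any claim that something is new, unique, unknown or untested is made for them only; others in the source may bear on it.

Measured compounds:
Compound 1 `O=C(/C=C/c1ccc2c(c1)B(O)OC2)c1cccc(F)c1` — in an ADME assay on L929 cells (Mus musculus) for cytotoxicity, read by resazurin assay, with a stated time of 72 h (on this read-out higher numbers stand for weaker inhibition and lower numbers for stronger inhibition), compound 1 gives > 10 ug/mL, which is a limit of the assay rather than a number.
Compound 2 `Cc1cccc(C(=O)/C=C/c2ccc3c(c2)B(O)OC3)c1` — in this assay compound 2 gives 8.56 ug/mL.
Compound 3 `Nc1cccc(C(=O)/C=C/c2ccc3c(c2)B(O)OC3)c1` — in this assay compound 3 gives 10 ug/mL.

Compound 3 stands highest of the two numbers, though its nearest neighbour is compound 2, at a 1.2-fold higher number from compound 2 to compound 3 (0.07 log units; within the scatter), a gap inside the scatter. The third value is the limit of > 10 ug/mL in this assay, at which 1 of the 3 values shown sits.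

Compound 4 `COCOc1cccc(C(=O)/C=C/c2ccc3c(c2)B(O)OC3)c1` differs from compound 3 by methoxymethoxy in place of amino on an aromatic carbon. For the measured compounds named here, the steps that bear on this are a 1.2-fold higher number from compound 2 to compound 3 (0.07 log units; within the scatter) and a number no higher from compound 1 to compound 3 (the limit leaves the size open), both exchanges at the same aromatic carbon, neither resolving a shift beyond the scatter. Going by the values given here, no measured step shows methoxymethoxy itself. Expected in this assay is therefore no step beyond the scatter, no change at the digits printed from compound 3 to compound 4 (within the scatter). Compound 4 is estimated at 10 ug/mL, within 5 ug/mL to 20 ug/mL.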

Compound 4, half-maximal inhibitory concentration: > 10 ug/mL
Compound 4 gave a limit, no number (the forecaster's own chance of this, stated with the estimate: 40%); the middle value sits exactly at the limit.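

In this assay, for the compounds shown here, methoxymethoxy on this aromatic carbon gives a number no lower from compound 3 to compound 4 (the limit leaves the size open), and an at least 1.1-fold higher number from compound 2 to compound 4 (0.06 log units; that floor lies within the scatter); no step at this position yet shows a number moving beyond the scatter. Compound 4 gives > 10 ug/mL, which is a limit of the assay and not a number. The step from compound 1 cannot be read, and the limit now recurs in the series: the limit of > 10 ug/mL in this assay, at which 2 of the 4 values shown sit.

Still open, on these data alone, is how far compound 1 and compound 4 lie past that limit. Also open, as far as these compounds go, is whether another group on this carbon, such as a carboxylic acid or a longer alkoxy chain, would shift the number beyond the scatter.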